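A few compounds are considered here, and "the series" means these few. Any claim that something is new, unique, unknown or untested is made for them only; others in the source may bear on it.

Measured compounds:
Compound 1 `COc1cc(-n2cnc3ccc(-c4ccc(Cl)cc4)cc32)cc(OC)c1OC` — in a functional assay on A549 cells (Homo sapiens) for antiproliferative activity, read by MTT assay, with a stated time of 72 h (a lower number here means a stronger inhibitor, a higher number a weaker inhibitor), compound 1 reaches only the assay limit, > 10000 nM.
Compound 2 `COc1cc(-n2cnc3ccc(-c4cccc(C)c4C)cc32)cc(OC)c1OC` — compound 2 gives 9250 nM.
Compound 3 `CCOc1ccc(-c2ccc3ncn(-c4cc(OC)c(OC)c(OC)c4)c3c2)cc1` — compound 3 gives 8550 nM.

Within the data shown here, only two of the three values are numbers; the value of compound 1 is a limit, (the limit of > 10000 nM in this assay, at which 1 of the 3 values shown sits). Compound 2 and compound 3 lie within the scatter of each other, as a 1.1-fold lower number from compound 2 to compound 3 (0.03 log units; within the scatter) shows, so neither can be called the stronger of the pair.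

Compound 4 `COc1ccc(-c2ccc3ncn(-c4cc(OC)c(OC)c(OC)c4)c3c2)cc1O` is not yet measured. It differs from compound 2 at one place: 3-hydroxy-4-methoxyphenyl in place of 2,3-dimethylphenyl on an aromatic carbon. Two measured steps change the same position on the shared core: an at least 1.0-fold lower number from compound 1 to compound 2 (0.03 log units; that floor lies within the scatter) and a 1.1-fold lower number from compound 2 to compound 3 (0.03 log units; within the scatter). Both are small, and the first starts from a limit, so together they suggest that swapping this aryl group moves the number little. Compound 4 is therefore expected to sit close to compound 2, with the step of a 1.9-fold lower number from compound 2 to compound 4 (0.27 log units; within the scatter) estimated and not beyond the scatter with confidence. For compound 4 the estimated value is 5000 nM, within 1000 nM to 15000 nM.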

Compound 4, half-maximal inhibitory concentration: 200 nM
Estimate against measurement, compound 4: 25-fold (1.40 log units) above; the measured number lies below the stated range.
By their numbers in this assay, from the lowest: compound 4; then compounds 3 and 2 (each within the scatter of the next). At a limit, above all of these: compound 1.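

In this assay, the aryl position that had looked indifferent to change proves decisive: 3-hydroxy-4-methoxyphenyl gives a 46-fold lower number from compound 2 to compound 4 (1.67 log units; beyond the scatter) and a 43-fold lower number from compound 3 to compound 4 (1.63 log units; beyond the scatter). Among these compounds, the 2,3-dimethylphenyl and 4-ethoxyphenyl groups could not be told apart, so the earlier compounds gave no sign that a change at this place could move the number so far. The step with an at least 50-fold lower number from compound 1 to compound 4 (1.69 log units; beyond the scatter) is only a floor, since compound 1 stands at a limit of the assay: the limit of > 10000 nM in this assay, at which 1 of the 4 values shown sits.

Hydroxy and methoxy enter together in compound 4, so the compounds shown cannot tell whether the step belongs to one of them or needs both. Also open, going by these compounds, is whether an amine in place of the hydroxy, or a longer alkoxy chain in place of the methoxy, would keep the gain.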